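Swapping Methyl for Fluoro on a Serotonin Receptor Agonist

The source may hold more compounds than are shown below. What is called first, only, known or untested is meant among the compounds shown, and "the series" means these compounds.

Measured so far:
Compound 1, `Fc1ccc(-c2noc3c2CCNCC3)cc1`, gives 38.2%
Compound 2, `Cc1ccc(-c2n[nH]c3c2CCNCC3)cc1`, gives 50.9%

Both compounds were tested in a functional assay on cells for agonist activity at 5-hydroxytryptamine receptor 7 (Homo sapiens), read by a luciferase reporter and beta-arrestin recruitment, with a stated time of 22 h (on this read-out higher numbers stand for larger maximal responses and lower numbers for smaller maximal responses), which reports how large a maximal response each compound produces. Compound 1 `Fc1ccc(-c2noc3c2CCNCC3)cc1` reaches 38.2%, while compound 2 `Cc1ccc(-c2n[nH]c3c2CCNCC3)cc1` reaches 50.9%. Of the two numbers, compound 2 stands highest; its nearest neighbour is compound 1, whose value lies lower by a gap that falls beyond the usual scatter of repeated measurements. Compound 1 and compound 2 differ in more than one place, so the gap between them cannot be pinned on a single change.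

Compound 3 `Fc1ccc(-c2n[nH]c3c2CCNCC3)cc1` keeps the core of compound 2 and differs from it in one spot: fluoro in place of methyl on an aromatic carbon. Among the measured compounds shown here, no measured pair shows this change on its own, so the size of the step in this assay can only be guessed. For the measured compounds named here, because compound 1, the only other compound carrying fluoro, gives 38.2%, the expectation for compound 3 is a small downward step or none beyond the scatter, as a number 5.9 percentage points lower from compound 2 to compound 3 (within the scatter). Compound 3 is therefore estimated at 45%, with a plausible range from 30% to 60%.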

Compound 3, largest response reached (Emax), in percent of the reference or control that the assay uses: 53.9%
The estimate for compound 3 lay 8.9 percentage points below the measured number; the measured number falls inside the stated range.
By their numbers in this assay, from the lowest: compound 1; then compounds 2 and 3 (each within the scatter of the next).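

In this assay, placing fluoro in place of methyl on the aromatic carbon para to a large group gives a number 3 percentage points higher from compound 2 to compound 3 (within the scatter) and so does not separate the two groups: at this position, this read-out treats them alike. This also adds something to the picture of compound 1, which carries the same fluoro: compound 1 gives 38.2% and compound 3 gives 53.9% in this assay, so fluoro by itself does not bring the lower number, and the one place where these two compounds differ lies in the core. Nothing measured here explains why methyl and fluoro give such similar maximal responses.

As far as these compounds go, it remains open whether this position would accept other groups equally well, such as methoxy, trifluoromethyl, an amine or a carboxylic acid, or whether the match seen here is limited to these two small substituents. From the compounds shown here alone, it is also open whether methyl and fluoro would match in the same way on the core of compound 1, since that core appears here with fluoro only.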